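Bromo to Iodo in a Growth Inhibition Series

This account rests on a few compounds, and the source may have more. Where it says the series, first, only, none or still open, it means among the compounds named here.

Among the measured compounds shown here, in a functional assay on SK-MEL-28 cells (Homo sapiens) for inhibition, read by sulforhodamine B assay, with a stated time of 48 h (a higher number here means a weaker inhibitor of growth, a lower number a stronger inhibitor of growth), compound 1 (`Cc1ccc(NC(=O)/C=C/c2ccccc2)c(C(N)=O)c1`) gives 5240 nM, while compound 2 (`NC(=O)c1cc(Br)ccc1NC(=O)/C=C/c1ccccc1`) gives 839 nM, the lower of the two numbers so far. Compound 3 (`NC(=O)c1cc(I)ccc1NC(=O)/C=C/c1ccccc1`) remains unmeasured. It carries iodo in place of bromo on an aromatic carbon, meta to a carbamoyl group and para to a large group: iodo in place of bromo on an aromatic carbon. For the measured compounds named here, only one measured step bears on this change, and only indirectly: a 6.2-fold lower number from compound 1 to compound 2 (0.80 log units; beyond the scatter), which is modest and replaces methyl with bromo. Going by the values given here, no measured compound carries iodo, so the data cannot settle this swap. A small step toward a lower number in this assay is therefore expected, possibly none beyond the scatter. The expected change is a 1.3-fold lower number from compound 2 to compound 3 (0.11 log units; within the scatter). For compound 3 the estimated value is 650 nM, within an expected range of 280 nM to 1500 nM.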

Compound 3, concentration for 50% growth inhibition: 2510 nM
Compound 3: middle estimate off by 3.9-fold (0.59 log units), on the low side, and the stated range ends below it.
By their numbers in this assay, from the lowest: compound 2; then compound 3; then compound 1.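

In this assay, the swap of bromo for iodo gives a 3.0-fold higher number from compound 2 to compound 3 (0.48 log units; beyond the scatter), so the lower number reached with bromo does not carry over to the next halogen at this position. Iodo still keeps part of the advantage over methyl, with a 2.1-fold lower number from compound 1 to compound 3 (0.32 log units; beyond the scatter), which places the three groups in the order bromo, iodo, methyl from the lowest number and shows that the two halogens are not interchangeable here. Nothing measured accounts for this difference between bromo and iodo.

The compounds shown leave open where chloro or fluoro would fall at this position, and so whether bromo stands out among the halogens at all. They also leave open whether a methoxy group or an amine in the same place would give a number lower than that of compound 2 839 nM.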